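Butyl in place of 4-chlorophenyl on a urea nitrogen

A few compounds are considered here, and "the series" means these few. Any claim that something is new, unique, unknown or untested is made for them only; others in the source may bear on it.

Measured compounds:
compound 1, `CC(C)CN(CC(C)C)c1ccc(/C(=N/O)Nc2ccc(F)c(Br)c2)cc1NC(=O)NC1CCCCC1`, 1340 nM
compound 2, `CC(C)CN(CC(C)C)c1ccc(/C(=N/O)Nc2ccc(F)c(Br)c2)cc1NC(=O)Nc1ccc(Cl)cc1`, 440 nM

In an assay on HeLa cells for inhibition of Indoleamine 2,3-dioxygenase 1 (Homo sapiens) (on this read-out higher numbers stand for weaker inhibition and lower numbers for stronger inhibition), compound 2 gives 440 nM, the lowest of the two numbers; its nearest neighbour is compound 1 at 1340 nM, and the step of a 3.0-fold lower number from compound 1 to compound 2 (0.48 log units; beyond the scatter) is modest yet beyond the scatter. Compound 3, `CCCCNC(=O)Nc1cc(/C(=N/O)Nc2ccc(F)c(Br)c2)ccc1N(CC(C)C)CC(C)C`, carries butyl in place of 4-chlorophenyl on an amide-type nitrogen. Going by the values given here, the only measured step that bears on this change is a 3.0-fold lower number from compound 1 to compound 2 (0.48 log units; beyond the scatter), in which 4-chlorophenyl replaced cyclohexyl on the same nitrogen and the number fell. Butyl, like cyclohexyl, brings no ring, so the expected step of a 2.7-fold higher number from compound 2 to compound 3 (0.44 log units; beyond the scatter) is an increase in this assay, roughly giving back that earlier gain, though the data hold no step from one non-ring group to another. Compound 3 is therefore estimated at about 1200 nM, with a range from 450 nM to 3200 nM.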

Compound 3, half-maximal inhibitory concentration: 3110 nM
The estimate for compound 3 lay 2.6-fold (0.41 log units) below the measured number; the measured number falls inside the stated range.
By their numbers in this assay, from the lowest: compound 2; then compound 1; then compound 3.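

At this amide-type nitrogen in this assay, butyl in place of 4-chlorophenyl gives a 7.1-fold higher number from compound 2 to compound 3 (0.85 log units; beyond the scatter), so the loss on leaving the aromatic ring is now visible with an open chain as well as with cyclohexyl. Cyclohexyl and butyl do not read alike either: butyl in place of cyclohexyl gives a 2.3-fold higher number from compound 1 to compound 3 (0.37 log units; beyond the scatter), which places the three groups in a clear order, with 4-chlorophenyl lowest, cyclohexyl in the middle and butyl highest. Nothing measured here explains that order.

The compounds shown cannot separate the part played by the aromatic ring from that of the chlorine, which a plain phenyl group on this nitrogen would address. As far as these compounds go, how far the number depends on the chain itself remains open too, and a longer chain such as hexyl, or butyl ending in an amine, would test that.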